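This account rests on a few compounds, and the source may have more. Where it says the series, first, only, none or still open, it means among the compounds named here.

In a functional assay on Ehrlich cells (Mus musculus) for cytotoxicity, read by trypan blue exclusion, with a stated time of 2 h, tested at 25 ug/mL (on this read-out higher numbers stand for a stronger effect at the one concentration tested and lower numbers for a weaker effect), compound 2 `CN(C)c1ccc(/C=N/C2=C(C#N)C(c3ccc(Cl)cc3Cl)C3=C(CCCC3=O)N2c2ccc(S(N)(=O)=O)cc2)cc1` gives 30%. Going by the values given here, its only measured neighbour, compound 1 `Cc1ccc(C(=O)NC2=C(C#N)C(c3ccc(Cl)cc3Cl)C3=C(CCCC3=O)N2c2ccc(S(N)(=O)=O)cc2)cc1`, gives 30% in this assay, so compound 2 stands level with it: the step of no change at the digits printed from compound 1 to compound 2 (within the scatter) swapped one aromatic group for another on the same double-bonded carbon without moving the read-out. Compound 3 `N#CC1=C(/N=C/c2ccc([N+](=O)[O-])cc2[N+](=O)[O-])N(c2ccc(S(N)(=O)=O)cc2)C2=C(C(=O)CCC2)C1c1ccc(Cl)cc1Cl` differs from compound 2 by 2,4-dinitrophenyl in place of 4-(dimethylamino)phenyl on a carbon with a double bond to nitrogen. Among the compounds with values here, since the one comparable step changed nothing beyond the scatter, the expected step of no change at the digits printed from compound 2 to compound 3 (within the scatter) is likewise none beyond the scatter. Compound 3 is therefore estimated at 30%, within a range from 18% to 52%.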

Compound 3, a percentage reported as activity, at one concentration (the size of the read-out at that concentration, not a potency): 20%
Compound 3: the middle estimate sits 10 percentage points above what was measured; low and high end bracket the measured number.
By their numbers in this assay, from the lowest: compounds 3, 1 and 2 (each within the scatter of the next).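

In this assay, replacing the 4-(dimethylamino)phenyl group with 2,4-dinitrophenyl, on a carbon with a double bond to nitrogen, gives a number 10 percentage points lower from compound 2 to compound 3 (within the scatter). So this position accepts a group with 12 heavy atoms and 4 hydrogen-bond acceptors in place of one with 9 and 1, without a change beyond the scatter. No supporting measurement bears on this result.

Still open, from the compounds shown here alone, is whether a non-aromatic group such as cyclohexyl at this carbon, or a carboxylic acid on its phenyl ring, would give the same read-out. A single concentration also leaves the potency of compound 3 open.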